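A few compounds are considered here, and "the series" means these few. Any claim that something is new, unique, unknown or untested is made for them only; others in the source may bear on it.

Of the compounds shown here, three with the same core have been tested in a functional assay on THP-1 cells (Homo sapiens) for inhibition, read by sulforhodamine B assay, with a stated time of 48 h, tested at 50 uM; on this read-out lower numbers stand for less inhibition of growth and higher numbers for more inhibition of growth at the one concentration tested: compound 1 `COc1ccc(/C=C/C(=O)/C=C/c2ccc(OCc3cn(CCCCCOc4cc(=O)oc5ccccc45)nn3)c(OC)c2)cc1OC` gives 47%, compound 2 `COc1cc(/C=C/C(=O)/C=C/c2cccc3ccccc23)ccc1OCc1cn(CCCCCOc2cc(=O)oc3ccccc23)nn1` gives 44%, and compound 3 `COc1cccc(/C=C/C(=O)/C=C/c2ccc(OCc3cn(CCCCCOc4cc(=O)oc5ccccc45)nn3)c(OC)c2)c1` gives 37%. Compound 3 therefore stands within the usual scatter of both others, and these numbers do not separate the three.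

The untested compound 4 `COc1cc(/C=C/C(=O)/C=C/c2cccs2)ccc1OCc1cn(CCCCCOc2cc(=O)oc3ccccc23)nn1` has thiophen-2-yl in place of 3-methoxyphenyl on a double-bonded chain carbon bound to a double-bonded chain carbon. Two measured swaps at this same place bear on the change: a number 3 percentage points lower from compound 1 to compound 2 (within the scatter) and a number 7 percentage points lower from compound 2 to compound 3 (within the scatter). Hydrogen in place of methoxy on an aromatic carbon gave a number 10 percentage points lower from compound 1 to compound 3 (within the scatter). Within the data shown here, none of these steps goes beyond the scatter, although no tested compound carries thiophen-2-yl. No step beyond the scatter is therefore expected in this assay. The estimated step is a number 3 percentage points higher from compound 3 to compound 4 (within the scatter). In this assay, compound 4 is expected at 40%, with an estimated range of 27% to 53%.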

Compound 4, percent growth inhibition at one concentration: 34%
Compound 4: middle estimate off by 6 percentage points, on the high side; the measured number falls inside the stated range.
By their numbers in this assay, from the lowest: compounds 4, 3, 2 and 1 (each within the scatter of the next, the first and the last beyond it).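

In this assay, placing thiophen-2-yl on the double-bonded chain carbon gives a number 3 percentage points lower from compound 3 to compound 4 (within the scatter) and a number 10 percentage points lower from compound 2 to compound 4 (within the scatter), so these numbers do not separate this five-membered sulfur ring from 3-methoxyphenyl or naphthalen-1-yl. Against 3,4-dimethoxyphenyl, the same swap gives a number 13 percentage points lower from compound 1 to compound 4 (beyond the scatter), the only step among these compounds that passes the scatter, which shows that the group at this place can shift growth inhibition, though only modestly. Nothing available for these compounds gives a reason for that step.

On these data alone, it remains open whether a phenyl ring carrying an amine or a carboxylic acid at this place would shift the number further. As far as these compounds go, whether the gap between compound 1 and compound 4 would hold at another concentration also stays open.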